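The source may hold more compounds than are shown below. What is called first, only, known or untested is meant among the compounds shown, and "the series" means these compounds.

Measured compounds:
compound 1, `CCCCCCN(C(C)=O)c1ccc(NC(C)=O)cc1SCC1CCCCC1`, 20400 nM in a functional assay on MCF7 cells (Homo sapiens) for antiproliferative activity, read by MTT assay, with a stated time of 48 h; a higher number here means a weaker inhibitor, a lower number a stronger inhibitor
compound 2, `CCCCCCSc1cc(NC(C)=O)ccc1N(CC1CCCCC1)C(C)=O`, 21000 nM in this assay

Compound 2 holds the higher of the two numbers in this assay, but its nearest neighbour compound 1 sits within the scatter of it, so the two values are read as indistinguishable. Both carry a hexyl chain and a cyclohexylmethyl group on the shared core, exchanged between the sulfur and the nitrogen, and the exchange leaves the half-maximal inhibitory concentration unchanged within the scatter.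

Compound 3, `CC(=O)Nc1ccc(N(CC2CCCCC2)C(C)=O)c(SCC2CCCCC2)c1`, is not yet measured in this assay. It differs from compound 2 by cyclohexyl in place of pentyl on a saturated chain carbon bound to a sulfur. Within the data shown here, with no step between measured compounds to draw on, and both neighbours clustered at the same level, no step beyond the scatter is expected in either direction. The expected step from compound 2 to compound 3 is a 1.2-fold lower number from compound 2 to compound 3 (0.07 log units; within the scatter). Compound 3 is estimated at 18000 nM, with a range from 8000 nM to 40000 nM.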

Compound 3, half-maximal inhibitory concentration: 16600 nM
For compound 3 the middle estimate is 1.1-fold (0.04 log units) above the measured one, and the stated range covers the measured number.
By their numbers in this assay, from the lowest: compounds 3, 1 and 2 (each within the scatter of the next).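

In this assay, cyclohexyl in place of pentyl on a saturated chain carbon bound to a sulfur reads as (a 1.3-fold lower number from compound 2 to compound 3 (0.10 log units; within the scatter)), and the same exchange on a saturated chain carbon bound to an amide-type nitrogen reads as (a 1.2-fold lower number from compound 1 to compound 3 (0.09 log units; within the scatter)). The earlier pair showed only that hexyl and cyclohexylmethyl could trade places between the sulfur and the nitrogen; these steps show that, at either place, the ring-bearing group and the open hexyl chain cannot be told apart in this read-out. No measurement on hand bears on this result.

On these data alone, all three compounds carry only hydrocarbon groups at these two places, so it stays open whether an amine or a carboxylic acid on the chain, or a much shorter chain such as methyl, would give a step beyond the scatter. The two places also cannot yet be ranked against each other.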